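A few compounds are considered here, and "the series" means these few. Any claim that something is new, unique, unknown or untested is made for them only; others in the source may bear on it.

Notes on the series in a functional assay on MCF7 cells (Homo sapiens) for antiproliferative activity, read by MTT assay, with a stated time of 48 h (on this read-out higher numbers stand for weaker inhibition and lower numbers for stronger inhibition), follow. Within the data shown here, compound 1 (`Cc1ccc2nc(NC(c3cn(-c4ccccc4)nc3-c3cccc(Cl)c3)c3c(O)ccc4ccccc34)sc2c1`) reads 49700 nM here, the highest of the three numbers so far and so the weakest inhibition among them. Compound 2 (`Cc1ccc(-c2nn(-c3ccccc3)cc2C(Nc2nc3cc(C)c(C)cc3s2)c2c(O)ccc3ccccc23)cc1`) reads 22400 nM and compound 3 (`COc1ccc2nc(NC(c3cn(-c4ccccc4)nc3-c3cccc(I)c3)c3c(O)ccc4ccccc34)sc2c1`) reads 20000 nM on the same scale. Both lie lower than compound 1 by more than the scatter, and they sit within the scatter of each other.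

Compound 4 (`Oc1ccc2ccccc2c1C(Nc1nc2ccc(Cl)cc2s1)c1cn(-c2ccccc2)nc1-c1cccc(Cl)c1`) is still unmeasured. Its difference from compound 1 is chloro in place of methyl on an aromatic carbon, which turns 6-methyl-1,3-benzothiazol-2-yl into 6-chloro-1,3-benzothiazol-2-yl. Among the measured compounds shown here, no measured pair differs in one place, so nothing shows this swap directly. In this assay no step beyond the scatter is expected, with a small drift to lower numbers as the likelier direction. The expected shift is a 1.2-fold lower number from compound 1 to compound 4 (0.09 log units; within the scatter) in estimated terms. For compound 4 the estimate is 40000 nM with an expected range of 17000 nM to 90000 nM as the working bracket.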

Compound 4, half-maximal inhibitory concentration: 17500 nM
Beside the measured number, compound 4's estimate is 2.3-fold (0.36 log units) above it, and the stated range covers the measured number.
By their numbers in this assay, from the lowest: compounds 4, 3 and 2 (each within the scatter of the next); then compound 1.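

In this assay, among these compounds, the change from 6-methyl-1,3-benzothiazol-2-yl to 6-chloro-1,3-benzothiazol-2-yl gives a 2.8-fold lower number from compound 1 to compound 4 (0.45 log units; beyond the scatter), the only step so far that can be read across a single place. A swap of one heavy atom on this aromatic carbon, with no hydrogen-bond donor or acceptor entering or leaving, is therefore enough to move the number beyond the scatter, although the step is modest. No measurement at hand bears on why chloro reads lower than methyl here.

Going by these compounds, whether other groups on this carbon, such as fluoro, trifluoromethyl or an amine, would read lower still or return towards the methyl value remains open. On these data alone, the swap also rests on this one pair, so whether it gives a similar step in the rest of the series is unknown.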